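The source may report more compounds than this note shows. Statements on the series, on what has been measured and on what is new or still open speak of the compounds shown alone.

Going by the values given here, compound 2 `COc1cccc(-c2cn3cc(-c4ccccc4)nc3c(N)n2)c1` stands highest of the two numbers measured so far in an assay on cells for displacement of a labelled ligand from transmembrane domain-containing protein TMIGD3 (Homo sapiens), read by scintillation counting, with a stated time of 120 min, tested at 1 uM (a higher number here means more inhibition at the concentration tested (going by the name of the read-out), a lower number less inhibition), where compound 2 gives 21%. Its nearest neighbour is compound 1 `Nc1nccn2cc(-c3ccccc3)nc12`, the shared core without any group at that position, which in this assay gives 12%; the step of a number 9 percentage points higher from compound 1 to compound 2 (within the scatter) stays within the scatter, so the two are not told apart. Compound 3 `Nc1nc(-c2ccc(Cl)cc2)cn2cc(-c3ccccc3)nc12` carries a different group at the same place: 4-chlorophenyl in place of 3-methoxyphenyl on an aromatic carbon. Among the compounds with values here, no measured step swaps one aryl group for another; the only step known, a number 9 percentage points higher from compound 1 to compound 2 (within the scatter), shows that adding the 3-methoxyphenyl moved the read-out by no more than the scatter. On that basis the exchange of 4-chlorophenyl for 3-methoxyphenyl is expected to give a step of a number 1 percentage points lower from compound 2 to compound 3 (within the scatter), no larger than the scatter. Compound 3 is therefore estimated at 20%, with a range from 5% to 40%.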

Compound 3, a percentage reported as inhibition, at one concentration (the size of the read-out at that concentration, not a potency): 1%
Estimate against measurement, compound 3: 19 percentage points above; the whole stated range lies above it.
By their numbers in this assay, from the lowest: compound 3; then compounds 1 and 2 (each within the scatter of the next).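

In this assay this position proves sensitive to which aryl group it carries: 4-chlorophenyl in place of 3-methoxyphenyl gives a number 20 percentage points lower from compound 2 to compound 3 (beyond the scatter), a change that clears the scatter, which the earlier step did not. The same 4-chlorophenyl in place of hydrogen gives a number 11 percentage points lower from compound 1 to compound 3 (beyond the scatter), so compound 3 lies lowest of the three, and a group at this carbon can lower the read-out rather than leave it unchanged. Nothing available accounts for this difference between the two aryl groups.

The swap alters both the substituent and its place on the phenyl ring, so the compounds shown cannot say which of the two matters; 3-chlorophenyl and 4-methoxyphenyl would separate them. Also open, as far as these compounds go, is how non-aryl groups at this carbon, such as an amine or a carboxylic acid, would behave.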